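Three Inactive Compounds and One Ethyl Change

The compounds below may be only part of what the source reports. "The series", "measured", "known", "first", "only" and "open" are said of these compounds alone.

Compound 1 `CC(C)c1cc2c(cc1O)[C@]13CCC[C@]4(C)CO[C@@H]1O[C@H]2C[C@@H]43`: > 10000 nM
Compound 2 `CC(C)c1cc2c(cc1O)[C@]13CCC[C@](C)(CO[C@H]1O)[C@@H]3CC2`: > 10000 nM
Compound 3 `CC(C)c1cc2c(cc1O)[C@]13CCC[C@](C)(CO[C@@H]1O)[C@@H]3CC2`: > 10000 nM

In a functional assay on A549 cells (Homo sapiens) for cytotoxicity, read by MTT assay, with a stated time of 24 h (on this read-out lower numbers stand for stronger inhibition and higher numbers for weaker inhibition), compound 2 gives > 10000 nM, which is a limit and not a number. It has no rank among the three compounds, since the data show (the limit of > 10000 nM in this assay, at which 3 of the 3 values shown sit).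

Compound 4 `CCO[C@@H]1OC[C@@]2(C)CCC[C@@]13c1cc(O)c(C(C)C)cc1CC[C@@H]23` keeps the core of compound 2 and differs in one place: ethyl in place of hydrogen on an oxygen on a saturated carbon. Put simply, hydroxy becomes ethoxy.

Within the data shown here, the only measured step close to this change is a step that the two limits leave unreadable from compound 2 to compound 3. That pair shows (the fact that compounds 2 and 3 differ only in the configuration as drawn), so it involves no new group and offers no size to carry over. Among the measured compounds shown here, no measured step covers an added ethyl.

Compound 2 sits at its limit of > 10000 nM, so compound 4 is expected to stay weak in this assay, with no firm direction of change. The estimated step is a step that the limit leaves unreadable from compound 2 to compound 4. For compound 4 the expected value is 15000 nM, within an estimated range of 5000 nM to 50000 nM.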

Compound 4, half-maximal inhibitory concentration: > 10000 nM
Compound 4 ended at the assay's limit (the forecaster's own chance of this, stated with the estimate: 65%); the middle value lies beyond the limit too.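

Compound 4 gives > 10000 nM, which is a limit and not a number. Among these compounds, compound 2 also sits at a limit, so no step between compound 2 and compound 4 can be read. The compounds shown leave open which change to the shared core would give a readable value in this assay at all.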